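A few compounds are considered here, and "the series" means these few. Any claim that something is new, unique, unknown or untested is made for them only; others in the source may bear on it.

Compound 1 `COc1ccc(/C=N/NC(=S)NC(C)(C)[C@H]2CC=C(C)CC2)cc1` is the only one of the three measured compounds to give a number: in a functional assay on OVCAR-3 cells (Homo sapiens) for inhibition, read by sulforhodamine B assay, with a stated time of 48 h (on this read-out higher numbers stand for weaker inhibition of growth and lower numbers for stronger inhibition of growth), compound 1 gives 7900 nM. Compound 2 `CC1=CC[C@H](C(C)(C)NC(=S)N/N=C/c2ccc(O)cc2)CC1` reaches only a limit of the assay, > 100000 nM, in this assay. Compound 3 `CC1=CC[C@H](C(C)(C)NC(=S)N/N=C/c2ccc(F)cc2)CC1` likewise gives only a limit, > 100000 nM. The step of an at least 12-fold higher number from compound 1 to compound 3 (1.10 log units; beyond the scatter), fluoro in place of methoxy on an aromatic carbon, and the step of an at least 12-fold higher number from compound 1 to compound 2 (1.10 log units; beyond the scatter) both end at the limit of > 100000 nM in this assay, at which 2 of the 3 values shown sit, while the step that the two limits leave unreadable from compound 2 to compound 3 cannot be read. Compound 4 `CC1=CC[C@H](C(C)(C)NC(=S)N/N=C/c2ccccc2Cl)CC1` differs from compound 3 by 2-chlorophenyl in place of 4-fluorophenyl on a carbon with a double bond to nitrogen. Among the compounds with values here, no measured step bears on this change directly; both measured steps away from compound 1 were large and upward. For compound 4 the expected step of a number no higher from compound 3 to compound 4 (the limit leaves the size open) is none beyond the scatter. Compound 4 is therefore estimated at 100000 nM, between 20000 nM and 300000 nM.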

Compound 4, concentration for 50% growth inhibition: 15100 nM
For compound 4 the middle estimate is 6.6-fold (0.82 log units) above the measured one; the whole stated range lies above it.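

With 2-chlorophenyl on the carbon with a double bond to nitrogen, the series gives a readable number again in this assay, with an at least 6.6-fold lower number from compound 3 to compound 4 (0.82 log units; beyond the scatter) and an at least 6.6-fold lower number from compound 2 to compound 4 (0.82 log units; beyond the scatter). Thus 4-methoxyphenyl is not the only group here that gives a number, since replacing it with 2-chlorophenyl gives a 1.9-fold higher number from compound 1 to compound 4 (0.28 log units; within the scatter). The first two steps stay open-ended because they start from a limit: the limit of > 100000 nM in this assay, at which 2 of the 4 values shown sit.

The halogen and its place on the ring change together, so the compounds shown do not separate the two. From the compounds shown here alone, how an amine or a nitrile on the aromatic ring would read in this assay also stays open.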